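The source may report more compounds than this note shows. Statements on the series, on what has been measured and on what is new or still open speak of the compounds shown alone.

Measured in an ADME assay on Vero cells (Chlorocebus sabaeus) for cytotoxicity, with a stated time of 72 h, tested at 50 ug/mL; on this read-out higher numbers stand for a stronger effect at the one concentration tested and lower numbers for a weaker effect:

- compound 1 `COc1ccc(N2CCn3c2n[nH]c(=O)c3=O)cc1`: 10%
- compound 2 `N=c1c(=O)[nH]nc2n1CCN2c1ccc(Cl)cc1`: 0%
- compound 3 `Cc1ccc(N2CCn3c2n[nH]c(=O)c3=O)cc1`: 0%

On these numbers compound 2 stands level with compound 3 at the digits shown, and its gap to compound 1 lies within the scatter, so none of the three can be told apart by this read-out. All three share a core, and the group on the aromatic carbon of the outer ring is what changes between them.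

The unmeasured compound 4 `Cc1ccc(N2CCn3c2n[nH]c(=O)c3=N)cc1` differs from compound 2 by methyl in place of chloro on an aromatic carbon.

Among the measured compounds shown here, no measured pair shows this exact exchange. For the measured compounds named here, the only step among the measured compounds that touches the same place is a number 10 percentage points lower from compound 1 to compound 3 (within the scatter), and it stays within the scatter. Everything measured so far sits at or near the bottom of the scale, and the one change of group at this position moved nothing beyond the scatter. For compound 4 the expectation is therefore no step beyond the scatter, a number 2 percentage points higher from compound 2 to compound 4 (within the scatter) in this assay. The estimate for compound 4 is 2%, with a range from 0% to 12%.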

Compound 4, a percentage reported as inhibition, at one concentration (the size of the read-out at that concentration, not a potency): 0%
Estimate against measurement, compound 4: 2 percentage points above; low and high end bracket the measured number.
By their numbers in this assay, from the lowest: compounds 2, 3, 4 and 1 (each within the scatter of the next).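

In this assay, putting methyl in place of chloro on the aromatic carbon para to a large group gives no change at the digits printed from compound 2 to compound 4 (within the scatter), so this place now has a second step that stays within the scatter, this time on the core of compound 2 and not on the core of compound 1. Chloro and methyl match in what can be counted, each with 1 heavy atom and with 0 hydrogen-bond donors and 0 hydrogen-bond acceptors, and compound 4 gives 0%, a reading at the very bottom of the scale, where a step downwards could not be seen at all. Nothing measured here explains why the number stays where it is.

From the compounds shown here alone, what stays open is whether a group of a different kind at this place, such as an amine, a carboxylic acid or a longer chain, would lift the number beyond the scatter. With every reading taken at a single concentration, the compounds shown also cannot tell how this pair would behave at a higher concentration.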